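Enlarging the side group of compound 2

A few compounds are considered here, and "the series" means these few. Any claim that something is new, unique, unknown or untested is made for them only; others in the source may bear on it.

Compound 1 `O=S(=O)(NCCN1CCCC1)c1cccc(-c2ccc3nccc(-c4ccnc(C(F)(F)F)c4)c3n2)c1`: 13000 nM
Compound 2 `CS(=O)(=O)Nc1cccc(-c2ccc3nccc(-c4ccncc4)c3n2)c1`: 13000 nM
Compound 3 `O=S(=O)(NCCO)c1cccc(Nc2ccc3nccc(-c4ccncc4)c3n2)c1`: 4000 nM

Going by the values given here, all three values come from an ADME assay on CHO cells (Cricetulus griseus) for cytotoxicity, read by MTT assay (on this read-out higher numbers stand for weaker inhibition and lower numbers for stronger inhibition), and are the only guide here. Compound 2 stands level with compound 1, and together they hold the highest number of the three, while compound 3 lies clearly lower. Compound 4 `C[C@@H]1CN(S(=O)(=O)c2cccc(-c3ccc4nccc(-c5ccncc5)c4n3)c2)C[C@H](C)N1` has (3,5-dimethylpiperazin-1-yl)sulfonyl in place of methanesulfonamido on an aromatic carbon of compound 2. Among the compounds with values here, no measured pair shows this change alone. With the known values running from compound 3 (4000 nM) to compound 2 (13000 nM), a small step towards lower numbers in this assay is expected, perhaps none beyond the scatter. The estimated step runs a 1.6-fold lower number from compound 2 to compound 4 (0.21 log units; within the scatter) and remains uncertain. For compound 4 the expected value is 8000 nM within an estimated range of 3000 nM to 20000 nM in this test.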

Compound 4, half-maximal inhibitory concentration: 6000 nM
Estimate against measurement, compound 4: 1.3-fold (0.12 log units) above; low and high end bracket the measured number.
By their numbers in this assay, from the lowest: compounds 3 and 4 (each within the scatter of the next); then compounds 1 and 2 (each within the scatter of the next).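

In this assay, going by these compounds alone, putting (3,5-dimethylpiperazin-1-yl)sulfonyl in place of methanesulfonamido on this aromatic carbon gives a 2.2-fold lower number from compound 2 to compound 4 (0.34 log units; beyond the scatter), a modest step and the first single change that can be read. This place therefore takes a much larger group with a ring, and the number falls only modestly. Nothing available shows the cause of this step.

On these data alone, it remains open whether the ring or its two methyl groups matter, which a plain piperazine or a morpholine could help separate. As far as these compounds go, how a carboxylic acid at this place would move the number also remains open.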